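This account rests on a few compounds, and the source may have more. Where it says the series, first, only, none or still open, it means among the compounds named here.

Compound 1, `COc1ccc(C(=O)ON=C2CC(c3ccc(O)c(OC)c3)N(C)C(c3ccc(O)c(OC)c3)C2)cc1`, gives 40000 nM in a functional assay on microsomes from liver (Rattus norvegicus, strain Wistar) for inhibition, read by spectrophotometry, with a stated time of 60 min; on this read-out lower numbers stand for stronger inhibition and higher numbers for weaker inhibition. Compound 2, `COc1ccc(C(=O)ON=C2CC(c3ccc(O)c(OC)c3)N(C)C(c3ccc(O)c(OC)c3)C2)c(OC)c1`, gives 52000 nM in this assay.

Compound 2 stands within the scatter of compound 1, the only other number shown: a 1.3-fold higher number from compound 1 to compound 2 (0.11 log units; within the scatter). Compound 3, `COc1cc(C2CC(=NOC(=O)c3ccccc3O)CC(c3ccc(O)c(OC)c3)N2C)ccc1O`, carries 2-hydroxyphenyl in place of 2,4-dimethoxyphenyl on a carbonyl carbon. For the measured compounds named here, the step from compound 1 to compound 2, which also swaps a methoxy for hydrogen on an aromatic carbon, is the only measured step that bears on this change, and it stayed within the scatter. He therefore expects no step beyond the scatter in this assay for compound 3: a 1.2-fold lower number from compound 2 to compound 3 (0.09 log units; within the scatter). Compound 3 is estimated at 42000 nM, between 15000 nM and 120000 nM.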

Compound 3, half-maximal inhibitory concentration: 24100 nM
Compound 3: the middle estimate sits 1.7-fold (0.24 log units) above what was measured, and the stated range covers the measured number.
By their numbers in this assay, from the lowest: compounds 3, 1 and 2 (each within the scatter of the next, the first and the last beyond it).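

For the compounds shown here, at this carbonyl carbon, 2-hydroxyphenyl in place of 2,4-dimethoxyphenyl gives the first step beyond the scatter in this assay (a 2.2-fold lower number from compound 2 to compound 3 (0.33 log units; beyond the scatter)), a modest one. Set against the 4-methoxyphenyl of compound 1, the same group stays within the scatter (a 1.7-fold lower number from compound 1 to compound 3 (0.22 log units; within the scatter)), so the change stands out against only one of the two compounds. Nothing available gives a reason for this step. The compounds shown leave open whether the hydroxy group or the loss of the methoxy groups carries the step. From the compounds shown here alone, how an amine or a carboxylic acid on this phenyl ring would read also stays open.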